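Solubility of compound 3 after the benzimidazole swap

This account rests on a few compounds, and the source may have more. Where it says the series, first, only, none or still open, it means among the compounds named here.

Measured in a physicochemical assay for solubility, read by chemiluminescence, in phosphate buffer, measured as kinetic solubility, at pH 7.4; a higher number here means a more soluble compound, a lower number a less soluble compound:
- Compound 1 `Cc1cnc(Nc2ccc(C(=O)NCC3(c4nc(-c5ccccc5)cs4)CCOCC3)cc2)s1`: < 1000 nM, a limit
- Compound 2 `Cn1c(Nc2ccc(C(=O)NCC3(c4nc(-c5ccccc5)cs4)CCOCC3)cc2)nc2ccccc21`: 10000 nM

Among the compounds with values here, compound 2 gives the only actual number, 10000 nM. Compound 1 sits at a limit of this assay, < 1000 nM.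

Compound 3 `O=C(NCC1(c2nc(-c3ccccc3)cs2)CCOCC1)c1ccc(Nc2nncs2)cc1` carries 1,3,4-thiadiazol-2-yl in place of 1-methyl-1H-benzimidazol-2-yl on a nitrogen on an aromatic ring.

Within the data shown here, the one measured step that bears on this is an at least 10-fold higher number from compound 1 to compound 2 (1.00 log units; beyond the scatter). Compound 3 again has a single five-membered ring at that place, so that step is expected to run largely in reverse, towards a lower number. The expected change is a 6.7-fold lower number from compound 2 to compound 3 (0.82 log units; beyond the scatter). Compound 3 is estimated at 1500 nM, within a range of 400 nM to 8000 nM.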

Compound 3, solubility: 29000 nM
Compound 3: the middle estimate sits 19-fold (1.29 log units) below what was measured; the measured number lies above the stated range.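

At this place, on a nitrogen on an aromatic ring, the number does not follow ring count: 1,3,4-thiadiazol-2-yl gives a 2.9-fold higher number from compound 2 to compound 3 (0.46 log units; beyond the scatter), although it replaces the two-ring 1-methyl-1H-benzimidazol-2-yl. Two single five-membered rings also part widely, with an at least 29-fold higher number from compound 1 to compound 3 (1.46 log units; beyond the scatter) when 1,3,4-thiadiazol-2-yl replaces 5-methyl-1,3-thiazol-2-yl. The value of compound 1 is a limit and not a number: the limit of < 1000 nM in this assay, at which 1 of the 3 values shown sits.

The compounds shown leave open whether that gap follows the methyl group or the ring atoms, and how an amine or a carboxylic acid on this ring would read.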